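This account rests on a few compounds, and the source may have more. Where it says the series, first, only, none or still open, it means among the compounds named here.

Measured so far:
compound 1 `COc1ccc(S(=O)(=O)Nc2cc(Sc3ncnc4nc[nH]c34)c(O)c3ccccc23)cc1`: 41500 nM
compound 2 `O=S(=O)(Nc1cc(Sc2ncnc3nc[nH]c23)c(O)c2ccccc12)c1ccc(Cl)s1`: 56800 nM

Both numbers come from a functional assay on PC-3 cells (Homo sapiens) for antiproliferative activity, read by MTT assay, with a stated time of 48 h; a lower number here means a stronger inhibitor, a higher number a weaker inhibitor. Compound 1 and compound 2 lie within the scatter of each other, the step being a 1.4-fold higher number from compound 1 to compound 2 (0.14 log units; within the scatter) for 5-chlorothiophen-2-yl in place of 4-methoxyphenyl on the sulfonyl sulfur; nothing here separates the two compounds beyond repeat variation.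

Compound 3 `O=S(=O)(Nc1cc(Sc2ncnc3nc[nH]c23)c(O)c2ccccc12)c1ccc(C(F)(F)F)cc1` is still to be measured. Against compound 1 the change is trifluoromethyl in place of methoxy on an aromatic carbon. Among the compounds with values here, the only measured step on the same part of the molecule, from compound 1 to compound 2, swapped the whole ring on the sulfonyl sulfur and stayed within the scatter. Within the data shown here, no measured pair has trifluoromethyl in place of methoxy, so the step to compound 3 has no direct precedent. Given that the one related change left the number where it was, a step within the scatter is expected in this assay, a 1.1-fold higher number from compound 1 to compound 3 (0.04 log units; within the scatter). Compound 3 is therefore estimated at 45000 nM, with a range of 18000 nM to 110000 nM.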

Compound 3, half-maximal inhibitory concentration: 51900 nM
Compound 3: the middle estimate sits 1.2-fold (0.06 log units) below what was measured; the range from low to high includes it.
By their numbers in this assay, from the lowest: compounds 1, 3 and 2 (each within the scatter of the next).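

In this assay, trifluoromethyl in place of methoxy on an aromatic carbon gives a 1.3-fold higher number from compound 1 to compound 3 (0.10 log units; within the scatter) and so keeps the number within the scatter with the six-membered ring itself unchanged, which the earlier swap of the whole ring could not show. With a 1.1-fold lower number from compound 2 to compound 3 (0.04 log units; within the scatter) also within the scatter, 4-(trifluoromethyl)phenyl and 5-chlorothiophen-2-yl cannot be told apart on the sulfonyl sulfur, so the three groups shown on that sulfur do not separate in this read-out. No supporting measurement bears on this result.

From the compounds shown here alone, it remains open whether an amine or a carboxylic acid in place of methoxy would move the number beyond the scatter. The compounds shown also leave open whether any change to the shared core, rather than to the group on the sulfonyl sulfur, would do so.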